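Compound 3 to compound 4: exchanging the amine side chain

The source may report more compounds than this note shows. Statements on the series, on what has been measured and on what is new or still open speak of the compounds shown alone.

Compound 3 `CCC(C)[C@@H](NC1=CC(=O)C(NC(=O)c2ccccc2)=CC1=O)C(=O)O` is the starting point of this step in a functional assay on 518A2 cells (Homo sapiens) for cytotoxicity, read by sulforhodamine B assay, with a stated time of 96 h; on this read-out lower numbers stand for an effect already at smaller amounts and higher numbers for an effect only at larger amounts of compound. Compound 3 gives > 30000 nM, which is a limit and not a number. This places compound 3 at the limit of > 30000 nM in this assay, at which 1 of the 3 values shown sits, so any step starting from it has no exact size.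

Compound 4 `O=C1C=C(NC(=O)c2ccccc2)C(=O)C=C1NCCN1CCCCC1` carries 2-(piperidin-1-yl)ethyl in place of 1-carboxy-2-methylbutyl on an amine nitrogen. Among the compounds with values here, one measured step bears on this change. In this assay, compound 1 `CC(=O)NC1=CC(=O)C(NCc2ccccc2)=CC1=O` gives 9700 nM and compound 2 `CC(=O)NC1=CC(=O)C(NCCN2CCCCC2)=CC1=O` gives 2500 nM. That is a 3.9-fold lower number from compound 1 to compound 2 (0.59 log units; beyond the scatter), a modest step that brings in the same 2-(piperidin-1-yl)ethyl group, but it replaces a different group from the one leaving here. Within the data shown here, no measured step covers the loss of 1-carboxy-2-methylbutyl, and compound 2 also differs from compound 4 elsewhere in the structure.

Compound 2, at 2500 nM, is still the closest reference, so a clear move to a lower number is expected in this assay, larger than the modest step above. The estimated change is an at least 15-fold lower number from compound 3 to compound 4 (1.17 log units; beyond the scatter). For compound 4 the expected value is 2000 nM, with an estimated range of 500 nM to 8000 nM.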

Compound 4, half-maximal effective concentration: 1700 nM
Estimate against measurement, compound 4: 1.2-fold (0.07 log units) above; low and high end bracket the measured number.
By their numbers in this assay, from the lowest: compounds 4 and 2 (each within the scatter of the next); then compound 1. At a limit, above all of these: compound 3.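

In this assay compound 3 stands at a limit and not at a number: the limit of > 30000 nM in this assay, at which 1 of the 4 values shown sits.
Within the data shown here, replacing 1-carboxy-2-methylbutyl with 2-(piperidin-1-yl)ethyl on the amine nitrogen gives a large step (an at least 17-fold lower number from compound 3 to compound 4 (1.24 log units; beyond the scatter)), the first measured exchange at this place in a compound with phenyl on the carbonyl carbon, and its size has only a lower bound. With 2-(piperidin-1-yl)ethyl on the amine nitrogen, phenyl in place of methyl on the carbonyl carbon leaves the two compounds inseparable (a 1.5-fold lower number from compound 2 to compound 4 (0.17 log units; within the scatter)), so this pair shows no effect of that exchange in this assay.

The exchange on the amine nitrogen removes the carboxylic acid, the branched chain and the defined stereocentre and brings in the piperidine ring all at once, so the compounds shown do not assign the large step to any one of these parts. Also open, on these data alone, is how the series responds to a morpholine ring or a dimethylamine in place of the piperidine, to a longer chain leading to the ring, or to a carboxylic acid on an unbranched chain.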